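The source may report more compounds than this note shows. Statements on the series, on what has been measured and on what is new or still open speak of the compounds shown alone.

Measured in a functional assay on CCRF-CEM cells (Homo sapiens) for inhibition; a higher number here means a weaker inhibitor, a lower number a stronger inhibitor:
compound 1 `OC[C@H]1OC(n2cnc3c(-c4ccoc4)ncnc32)[C@H](O)[C@@H]1O` gives 1650 nM
compound 2 `OC[C@H]1OC(n2cnc3c(-c4ccccn4)ncnc32)[C@H](O)[C@@H]1O` gives 900 nM
compound 3 `OC[C@H]1OC(n2cnc3c(-c4cc5ccccc5o4)ncnc32)[C@H](O)[C@@H]1O` gives 15000 nM

Compound 1 holds the second highest of the three numbers in this assay. Its nearest neighbour is compound 2, reached by a 1.8-fold lower number from compound 1 to compound 2 (0.26 log units; within the scatter), a step within the scatter; the furthest is compound 3, reached by a 9.1-fold higher number from compound 1 to compound 3 (0.96 log units; beyond the scatter), a step beyond it. The step of a 17-fold higher number from compound 2 to compound 3 (1.22 log units; beyond the scatter) confirms that the 1-benzofuran-2-yl compound 3 is the weakest of the three.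

Compound 4 `OC[C@H]1OC(n2cnc3c(-c4cc[nH]n4)ncnc32)[C@H](O)[C@@H]1O` is not yet measured in this assay. It differs from compound 1 in one place: 1H-pyrazol-3-yl in place of furan-3-yl on an aromatic carbon. Among the compounds with values here, no measured step exchanges one single five-membered ring for another, so the bearing of the measured steps is indirect. Within the data shown here, the only step beyond the scatter, a 9.1-fold higher number from compound 1 to compound 3 (0.96 log units; beyond the scatter), comes with the 1-benzofuran-2-yl group; compound 4 keeps a single five-membered ring. Because a 1.8-fold lower number from compound 1 to compound 2 (0.26 log units; within the scatter) stayed within the scatter when furan-3-yl gave way to pyridin-2-yl, compound 4 is expected to sit close to compound 1, with the step of a 1.3-fold lower number from compound 1 to compound 4 (0.10 log units; within the scatter) inside the scatter. The estimate for compound 4 in this assay is 1300 nM, within the range 400 nM to 4500 nM.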

Compound 4, half-maximal inhibitory concentration: 750 nM
For compound 4 the middle estimate is 1.7-fold (0.24 log units) above the measured one; low and high end bracket the measured number.
By their numbers in this assay, from the lowest: compounds 4, 2 and 1 (each within the scatter of the next, the first and the last beyond it); then compound 3.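

In this assay, exchanging one single five-membered aromatic ring for another at this carbon, with the count of 5 heavy atoms unchanged, moves the number beyond the scatter: a 2.2-fold lower number from compound 1 to compound 4 (0.34 log units; beyond the scatter), as 1H-pyrazol-3-yl with 2 hetero atoms and 1 hydrogen-bond donor replaces furan-3-yl with 1 hetero atom and 0 hydrogen-bond donors. The position therefore responds to the identity of a small ring and not only to the large change to 1-benzofuran-2-yl, and the gap to that group widens to a 20-fold lower number from compound 3 to compound 4 (1.30 log units; beyond the scatter), whereas 1H-pyrazol-3-yl and pyridin-2-yl cannot be told apart at a 1.2-fold lower number from compound 2 to compound 4 (0.08 log units; within the scatter). No measurement shown here explains the gain over furan-3-yl.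

Still open, as far as these compounds go, is whether the hydrogen on the pyrazole nitrogen or the second ring nitrogen carries the step, a question that a 1-methylpyrazol-3-yl group would address. Equally open, from the compounds shown here alone, is how this carbon responds to a non-aromatic substituent such as an amine or a carboxylic acid.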